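Fluoromethylphenyl variants of the fused pyranone core

The source may report more compounds than this note shows. Statements on the series, on what has been measured and on what is new or still open speak of the compounds shown alone.

In a functional assay on KB cells (Homo sapiens) for antiproliferative activity, read by sulforhodamine B assay, with a stated time of 3 days (on this read-out higher numbers stand for an effect only at larger amounts of compound and lower numbers for an effect already at smaller amounts), the lowest number among the three measured analogues belongs to compound 3 `CCC1=C(O)c2c(oc(-c3cc(C)c(C)cc3C)cc2=O)C(CC)(CC)C1=O`: compound 3 gives 8.2 uM. The nearest of the others is compound 1 `CCC1=C(O)c2c(oc(-c3ccc(O)cc3)cc2=O)C(CC)(CC)C1=O` with 20.6 uM, the step being a 2.5-fold lower number from compound 1 to compound 3 (0.40 log units; beyond the scatter). Furthest is compound 2 `CCC1=C(O)c2c(oc(-c3ccc(C)c(F)c3)cc2=O)C(CC)(CC)C1=O` with 28.1 uM, the step being a 3.4-fold lower number from compound 2 to compound 3 (0.53 log units; beyond the scatter); on the shown data compound 3 is the most potent of the three.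

Compound 4 `CCC1=C(O)c2c(oc(-c3ccc(F)c(C)c3)cc2=O)C(CC)(CC)C1=O` is not yet measured. The change from compound 3 to compound 4 is 4-fluoro-3-methylphenyl in place of 2,4,5-trimethylphenyl on an aromatic carbon. The 4-fluoro-3-methylphenyl of compound 4 is the closest neighbour, among the measured groups, of the 3-fluoro-4-methylphenyl of compound 2, so the step of a 3.4-fold lower number from compound 2 to compound 3 (0.53 log units; beyond the scatter) is the most relevant and is here run in reverse; the step of a 2.5-fold lower number from compound 1 to compound 3 (0.40 log units; beyond the scatter) points the same way. Both replacements of 2,4,5-trimethylphenyl by a smaller aryl group gave higher numbers beyond the scatter, so a modest rise is expected for compound 4 in this assay, roughly back to the level of compounds 1 and 2. The expected step is a 2.7-fold higher number from compound 3 to compound 4 (0.43 log units; beyond the scatter). Compound 4 is estimated at 22 uM, with a range from 9 uM to 50 uM.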

Compound 4, concentration for half-maximal effect: 40.5 uM
Beside the measured number, compound 4's estimate is 1.8-fold (0.27 log units) below it; low and high end bracket the measured number.
By their numbers in this assay, from the lowest: compound 3; then compounds 1, 2 and 4 (each within the scatter of the next).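

In this assay, 4-fluoro-3-methylphenyl in place of 2,4,5-trimethylphenyl on this aromatic carbon gives a 4.9-fold higher number from compound 3 to compound 4 (0.69 log units; beyond the scatter), and with this step compound 3 stands apart from all three other analogues, each of its steps being beyond the scatter. The two fluoromethylphenyl isomers are not separated by this read-out, with a 1.4-fold higher number from compound 2 to compound 4 (0.16 log units; within the scatter), and neither are the 4-hydroxyphenyl and 4-fluoro-3-methylphenyl groups, with a 2.0-fold higher number from compound 1 to compound 4 (0.29 log units; within the scatter), so compounds 1, 2 and 4 form one level with only compound 3 below it. Nothing measured on these compounds bears on why the 2,4,5-trimethylphenyl group stands apart.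

The compounds shown do not tell whether the lower number of compound 3 needs all three methyl groups or would hold with a dimethylphenyl or a single methylphenyl group at this position. They also leave open how an aminophenyl group, a carboxylic acid on the aryl ring, or ethyl chains in place of the methyl groups would read here, and whether any aryl group can go below compound 3 at 8.2 uM.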